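Methyl for bromo on the pendant phenyl ring

The compounds below may be only part of what the source reports. "The series", "measured", "known", "first", "only" and "open" are said of these compounds alone.

Measured compounds in a functional assay on MCF7 cells (Homo sapiens) for cytotoxicity, read by MTT assay, with a stated time of 72 h; on this read-out higher numbers stand for weaker inhibition and lower numbers for stronger inhibition:
- compound 1 `O=C(Nc1ccc(Oc2ccnc3[nH]ccc23)c(F)c1)c1cc(-c2ccc(F)cc2)ncn1`: compound 1 gives "not active" (no number reported), with no number reported
- compound 2 `O=C(Nc1ccc(Oc2ccnc3[nH]ccc23)c(F)c1)c1cc(-c2ccc(C(F)(F)F)cc2)ncn1`: compound 2 gives 2840 nM
- compound 3 `O=C(Nc1ccc(Oc2ccnc3[nH]ccc23)c(F)c1)c1cc(-c2ccc(Br)cc2)ncn1`: compound 3 gives 10300 nM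

Compound 3 holds the highest of the two numbers in this assay; its nearest neighbour is compound 2, and the step of a 3.6-fold higher number from compound 2 to compound 3 (0.56 log units; beyond the scatter) lies beyond the scatter. Compound 1 gives no number at all in this assay.

Compound 4 `Cc1ccc(-c2cc(C(=O)Nc3ccc(Oc4ccnc5[nH]ccc45)c(F)c3)ncn2)cc1` differs from compound 3 in one place: methyl in place of bromo on an aromatic carbon. Within the data shown here, no measured step covers this exchange directly. Among the measured compounds shown here, the only step available, a 3.6-fold higher number from compound 2 to compound 3 (0.56 log units; beyond the scatter), shows that swapping the group on this phenyl ring can shift the number by a modest amount, and compound 1 shows that one such swap can remove measurable activity altogether. The step of a 1.5-fold higher number from compound 3 to compound 4 (0.16 log units; within the scatter) is therefore expected to be small in the direction of a higher number, though an absence of any number is also plausible. Compound 4 is estimated at 15000 nM, with a range from 5000 nM to 50000 nM.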

Compound 4, half-maximal inhibitory concentration: 6730 nM
Compound 4: the middle estimate sits 2.2-fold (0.35 log units) above what was measured; measured number inside the range.
By their numbers in this assay, from the lowest: compound 2; then compounds 4 and 3 (each within the scatter of the next).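

In this assay, methyl and bromo on this aromatic carbon cannot be told apart, as a 1.5-fold lower number from compound 3 to compound 4 (0.18 log units; within the scatter) shows, so a halogen atom at this place is not needed for a measurable number of this size. Trifluoromethyl, by contrast, stands clear of methyl as well as of bromo, with a 2.4-fold higher number from compound 2 to compound 4 (0.37 log units; beyond the scatter), which leaves compound 2 as the only one of the three numbered compounds separated from the others. Nothing measured here accounts for these differences.

The compounds shown leave open how an amine, a hydroxyl or a carboxylic acid on this carbon would read, and whether a longer chain such as ethyl or propyl would stay with methyl or move toward trifluoromethyl. They also leave open why compound 1, with its fluoro group, gives "not active" (no number reported) while the other three give numbers.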